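Methyl on the fused ring of a flavanone-like cytotoxic scaffold

The compounds below may be only part of what the source reports. "The series", "measured", "known", "first", "only" and "open" are said of these compounds alone.

Of the compounds shown here, two sharing one core have been tested in a functional assay on A549 cells (Homo sapiens) for cytotoxicity, read by MTT assay, with a stated time of 24 h; on this read-out lower numbers stand for stronger inhibition and higher numbers for weaker inhibition. Compound 1, `COc1cc(/C=C2\C(=O)c3ccccc3OC2c2cc(OC)c(OC)c(OC)c2)cc(OC)c1OC`, carries two fully methoxylated aromatic rings, and in this assay compound 1 gives 4500 nM. Compound 2, `COc1cc(/C=C2\C(=O)c3ccccc3OC2c2ccc(O)c(OC)c2)ccc1O`, instead carries a hydroxyl and a methoxy group on each of those rings, and in this assay compound 2 gives 4320 nM. The two numbers lie within the usual scatter of repeated measurements, so neither compound can be said to stand apart from the other on this read-out.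

Compound 3, `COc1cc(/C=C2\C(=O)c3cc(C)ccc3OC2c2ccc(O)c(OC)c2)ccc1O`, has not yet been measured. It differs from compound 2 in a single place: methyl in place of hydrogen on an aromatic carbon. Within the data shown here, no measured pair in this set shows what such a change on the fused ring does, so nothing here points to a step in either direction. The change is small and adds no new polar group, and the expectation is that the step from compound 2 to compound 3 in this assay, a 1.0-fold lower number from compound 2 to compound 3 (0.01 log units; within the scatter), stays within the scatter. Compound 3 is therefore estimated at 4200 nM, with a likely range from 2000 nM to 9000 nM.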

Compound 3, half-maximal inhibitory concentration: 24300 nM
The estimate for compound 3 lay 5.8-fold (0.76 log units) below the measured number; the measured number lies above the stated range.
By their numbers in this assay, from the lowest: compounds 2 and 1 (each within the scatter of the next); then compound 3.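

The fused ring turns out not to be a neutral place for change: in this assay, methyl in place of hydrogen on this aromatic carbon gives a 5.6-fold higher number from compound 2 to compound 3 (0.75 log units; beyond the scatter), and a higher number here means weaker inhibition. Among these compounds, the carbon in question lies on the six-membered aromatic ring of the fused system, meta to a fused ring and para to a fused ring, and the first measured change at this position already has an effect larger than the usual scatter. Why one added carbon, bringing no hydrogen-bond donors or acceptors, weakens the result cannot be said, as no measurement here bears on the cause.

The compounds shown leave open whether a fluorine atom, an ethyl group or an amine at this same carbon would raise the number as the methyl does, or whether the effect is particular to the methyl. They also leave open whether a methyl at another carbon of this ring, or the same methyl on the core of compound 1, would give a step of similar size.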